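Taking the side chain off compound 1

This account rests on a few compounds, and the source may have more. Where it says the series, first, only, none or still open, it means among the compounds named here.

Among the measured compounds shown here, in an ADME assay on MDBK cells (Bos taurus) for cytotoxicity, read by MTT assay, with a stated time of 96 h (on this read-out higher numbers stand for lower toxicity in this test and lower numbers for higher toxicity in this test), compound 1 `CN(C)CCCN(/N=N/c1ccccc1)c1cccc(C(F)(F)F)c1` gives 38000 nM, the only exact number so far. Compound 2 `CN(C)CCCN(/N=N/c1cc(F)ccc1F)c1cccc(C(F)(F)F)c1` reaches only a limit of the assay, > 100000 nM. Compound 3 `FC(F)(F)c1cccc(N/N=N/c2ccccc2)c1` has hydrogen in place of 3-(dimethylamino)propyl on a nitrogen on an aromatic ring. For the measured compounds named here, the one measured step, an at least 2.6-fold higher number from compound 1 to compound 2 (0.42 log units; beyond the scatter), puts 2,5-difluorophenyl in place of phenyl on a double-bonded nitrogen, a different change that sets no size here. No shift beyond the scatter is therefore expected in this assay, only an estimated 1.1-fold higher number from compound 1 to compound 3 (0.02 log units; within the scatter). For compound 3 the estimate is 40000 nM, within a range from 12000 nM to 100000 nM.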

Compound 3, half-maximal cytotoxic concentration: > 100000 nM
Compound 3: no number, only a limit; the forecaster's own chance of this, stated with the estimate: 25%; at least 2.5-fold (0.39 log units) between middle value and limit.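

Among the compounds shown here, putting hydrogen in place of 3-(dimethylamino)propyl on this nitrogen gives an at least 2.6-fold higher number from compound 1 to compound 3 (0.42 log units; beyond the scatter) in this assay, so the lower number of compound 1 depends on this side chain, something the earlier compounds could not show. The value of compound 3 is a limit of the assay, not a number. How far compound 2 and compound 3 stand apart cannot be told, because both stop at the same limit: the limit of > 100000 nM in this assay, at which 2 of the 3 values shown sit.

Still open, going by these compounds, is whether a primary amine or a shorter chain on this nitrogen would keep the number of compound 1 or move it towards the limit.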